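A Trifluoromethylphenyl Replaces a Dichlorophenyl on the Core

The source may hold more compounds than are shown below. What is called first, only, known or untested is meant among the compounds shown, and "the series" means these compounds.

Of the compounds shown here, three built on one shared core have been tested in a functional assay on BGC-823 cells (Homo sapiens) for antiproliferative activity, read by MTT assay, tested at 1 uM; a higher number here means a stronger effect of the compound at the concentration tested, a lower number a weaker effect. Compound 1 `COc1ccc(C2OC(c3cc(OC)c(OC)c(OC)c3)=NN2C(C)=O)c(OC)c1` gives 6.3%. Compound 2 `COc1ccc(OC)c(C2OC(c3cc(OC)c(OC)c(OC)c3)=NN2C(C)=O)c1` gives 0.4%, and compound 3 `COc1cc(C2=NN(C(C)=O)C(c3ccc(Cl)c(Cl)c3)O2)cc(OC)c1OC` gives -0.8%. On the numbers shown, compound 3 stands at the bottom of the three, yet this is only a nominal position: the step of a number 7.1 percentage points lower from compound 1 to compound 3 (within the scatter) and the step of a number 1.2 percentage points lower from compound 2 to compound 3 (within the scatter) are both within the scatter, so none of the three can be told apart from the others by this measurement.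

Compound 4 `COc1cc(C2=NN(C(C)=O)C(c3cccc(C(F)(F)F)c3)O2)cc(OC)c1OC` has not yet been measured. It differs from compound 3 in one place: 3-(trifluoromethyl)phenyl in place of 3,4-dichlorophenyl on a saturated ring carbon. The measured steps that bear on this change are the two in which the group on that same saturated ring carbon was exchanged, a number 7.1 percentage points lower from compound 1 to compound 3 (within the scatter) and a number 1.2 percentage points lower from compound 2 to compound 3 (within the scatter), where a different substituent pattern on the phenyl ring left the number within the scatter each time. A further exchange on that carbon is therefore expected to produce a step of a number 2.8 percentage points higher from compound 3 to compound 4 (within the scatter) in this assay, that is, nothing beyond the scatter. Compound 4 is estimated at 2%, with a range from -12% to 16%.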

Compound 4, a percentage reported as inhibition, at one concentration (the size of the read-out at that concentration, not a potency): 27.9%
Compound 4: the middle estimate sits 25.9 percentage points below what was measured; the measured number lies above the stated range.
By their numbers in this assay, from the lowest: compounds 3, 2 and 1 (each within the scatter of the next); then compound 4.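

In this assay, the saturated ring carbon of the shared core now proves sensitive to which aryl group it carries: exchanges among 2,4-dimethoxyphenyl, 2,5-dimethoxyphenyl and 3,4-dichlorophenyl stayed within the scatter, whereas the exchange for 3-(trifluoromethyl)phenyl gives a number 28.7 percentage points higher from compound 3 to compound 4 (beyond the scatter). The same group also separates clearly from both dimethoxyphenyl groups, with a number 27.5 percentage points higher from compound 2 to compound 4 (beyond the scatter) and a number 21.6 percentage points higher from compound 1 to compound 4 (beyond the scatter), which makes compound 4 the only one of the four set apart from all the others. No measurement is available that explains this difference.

Since 3,4-dichlorophenyl leaves as 3-(trifluoromethyl)phenyl enters, the compounds shown cannot separate the loss of the two chlorine atoms from the arrival of the trifluoromethyl group, and it remains open whether a plain phenyl, a phenyl with a single chlorine, or a phenyl with a nitrile or a methyl group would behave like compound 4. The read-out also comes from a single concentration, so it shows the size of the effect at that concentration and leaves the potency of compound 4 unknown.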